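The source may report more compounds than this note shows. Statements on the series, on what has been measured and on what is new or still open speak of the compounds shown alone.

Compound 3 `O=S(=O)(Nc1ccccc1)c1ccc(F)c2ncc(I)cc12` gives 23900 nM in an assay for inhibition of methylcytosine dioxygenase TET2 (Homo sapiens), read by mass spectrometry, with stated times of 30 min and 1 h (on this read-out lower numbers stand for stronger inhibition and higher numbers for weaker inhibition), the highest of the two numbers shown there. Compound 1 `Cc1oncc1NS(=O)(=O)c1ccc(F)c2ncc(I)cc12` gives 2100 nM, and the change from its 5-methyl-1,2-oxazol-4-yl to phenyl on the sulfonamide nitrogen brings an 11-fold higher number from compound 1 to compound 3 (1.06 log units; beyond the scatter). Compound 2 `CNS(=O)(=O)c1ccc(F)c2ncc(I)cc12` gives only a limit of this assay, > 200000 nM, which is the limit of > 200000 nM in this assay, at which 1 of the 3 values shown sits. Replacing methyl with phenyl gives an at least 8.3-fold lower number from compound 2 to compound 3 (0.92 log units; beyond the scatter), and methyl in place of the oxazole gives an at least 95-fold higher number from compound 1 to compound 2 (1.97 log units; beyond the scatter).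

Compound 4 `O=S(=O)(Nc1cccc(O)c1)c1ccc(F)c2ncc(I)cc12` differs from compound 3 by hydroxy in place of hydrogen on an aromatic carbon. Among the measured compounds shown here, none of the measured steps adds a hydroxy to a ring; each exchanges the whole group on the sulfonamide nitrogen, so they offer no direct guide. A step within the scatter, a 1.6-fold lower number from compound 3 to compound 4 (0.20 log units; within the scatter), is expected. Compound 4 is therefore estimated at 15000 nM, between 5000 nM and 60000 nM.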

Compound 4, half-maximal inhibitory concentration: > 200000 nM
Compound 4 ended at the assay's limit (the forecaster's own chance of this, stated with the estimate: 5%); middle value at least 13-fold (1.12 log units) away from the limit.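

A single hydroxy on the phenyl ring turns weak inhibition into none that this read-out can put a number on (an at least 8.3-fold higher number from compound 3 to compound 4 (0.92 log units; beyond the scatter)), so this ring carbon is far from indifferent to the change. The 3-hydroxyphenyl group also falls far behind the 5-methyl-1,2-oxazol-4-yl group (an at least 95-fold higher number from compound 1 to compound 4 (1.97 log units; beyond the scatter)). Compound 4 and compound 2 each give only a limit, not a number, so the step between them cannot be read: the limit of > 200000 nM in this assay, at which 2 of the 4 values shown sit.

As far as these compounds go, how far compound 4 lies past its limit stays open. Also open, from the compounds shown here alone, is whether any group at this carbon would do the same, since a methoxy or an amine there would separate the effect of hydroxy from that of substitution as such.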